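A few compounds are considered here, and "the series" means these few. Any claim that something is new, unique, unknown or untested is made for them only; others in the source may bear on it.

Compound 1 `Cc1ccnc(NC(c2ccccc2F)c2ccc3cccnc3c2O)c1`: 13100 nM
Compound 2 `Cc1ccnc(NC(c2cc(C)ccc2C)c2ccc3cccnc3c2O)c1`: > 10000 nM (a limit)

Both compounds were tested in a functional assay on U-87MG ATCC cells for inhibition, with U-87 MG (Homo sapiens) as the target, read by MTT assay, with a stated time of 72 h; a higher number here means a weaker inhibitor, a lower number a stronger inhibitor. Compound 2 gives no number, only a limit of the assay: > 10000 nM.

Compound 3 `Cc1ccnc(NC(c2ccc3cccnc3c2O)c2c(Cl)cccc2Cl)c1` differs from compound 2 in one place, on a saturated chain carbon bound to an aromatic carbon and a nitrogen on an aromatic ring, where 2,6-dichlorophenyl stands in place of 2,5-dimethylphenyl: 2,6-dichlorophenyl in place of 2,5-dimethylphenyl on a saturated chain carbon bound to an aromatic carbon and a nitrogen on an aromatic ring.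

For the measured compounds named here, only one measured step bears on this place: a step that the limit leaves unreadable from compound 1 to compound 2. It swapped 2-fluorophenyl for 2,5-dimethylphenyl, and its size cannot be read, so it sets no direction for the new change. Going by the values given here, the only true number therefore comes from compound 1, at 13100 nM, and the expectation is anchored there. No step beyond the scatter is expected in this assay, and the estimate is a number no higher from compound 2 to compound 3 (the limit leaves the size open). The expected value for compound 3 is 10000 nM, with an estimated range from 3500 nM to 30000 nM.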

Compound 3, half-maximal inhibitory concentration: 7200 nM
Estimate against measurement, compound 3: 1.4-fold (0.14 log units) above; low and high end bracket the measured number.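

With compound 3, the position on the saturated chain carbon gets its first readable comparison in this assay: 2,6-dichlorophenyl in place of 2-fluorophenyl gives a 1.8-fold lower number from compound 1 to compound 3 (0.26 log units; within the scatter), so these two groups cannot be told apart in this assay. Set against 2,5-dimethylphenyl, the same 2,6-dichlorophenyl group gives an at least 1.3-fold lower number from compound 2 to compound 3 (0.14 log units; that floor lies within the scatter), and only this floor of the step can be read, not its full size. The step from compound 1 to compound 2 still cannot be read, because compound 2 carries only a limit: the limit of > 10000 nM in this assay, at which 1 of the 3 values shown sits.

From the compounds shown here alone, how far compound 2 lies past its limit stays open, and with it whether the change from 2,5-dimethylphenyl to 2,6-dichlorophenyl reaches beyond the scatter. The compounds shown also do not tell whether any group at this place can move the number beyond the scatter, as a phenyl ring carrying an amine or a carboxylic acid, or a longer chain standing in place of the ring, might or might not do.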